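Compound 3: adding 4-hydroxy-4-methylcyclohexyl to compound 1

A few compounds are considered here, and "the series" means these few. Any claim that something is new, unique, unknown or untested is made for them only; others in the source may bear on it.

Measured so far in a functional assay on CAL-51 cells (Homo sapiens) for antiproliferative activity, read by luminescence and CellTiter-Glo, with a stated time of 3 days; a higher number here means a weaker inhibitor, a lower number a stronger inhibitor:
- compound 1 `COc1cc(C(=O)N(C)C)ccc1Nc1nc(OC2CCCCC2)c2cc[nH]c2n1` gives 190 nM as its value
- compound 2 `CN(C)C(=O)c1ccc(Nc2nc(O[C@H]3CC[C@@](C)(O)CC3)c3cc[nH]c3n2)c(OCC(F)(F)F)c1` gives 15 nM as its value

Compound 1 holds the higher of the two numbers, and the gap to compound 2 lies beyond the scatter. Not yet measured is compound 3 `COc1cc(C(=O)N(C)C)ccc1Nc1nc(O[C@H]2CC[C@](C)(O)CC2)c2cc[nH]c2n1` in this series. It carries 4-hydroxy-4-methylcyclohexyl in place of the cyclohexyl of compound 1 on an oxygen on an aromatic ring, with 4-hydroxy-4-methylcyclohexyl in place of cyclohexyl on an oxygen on an aromatic ring as the counted change. No measured pair differs in one place only, so the size of this change in this assay has not been shown directly. Compound 2 also carries 4-hydroxy-4-methylcyclohexyl and gives 15 nM as its value, so a lower number is expected, though this is only a loose guide. An estimated 3.2-fold lower number from compound 1 to compound 3 (0.50 log units; beyond the scatter) is expected, beyond the scatter but smaller than the gap between the measured compounds. Compound 3 is expected at 60 nM with an estimated range from 18 nM to 200 nM as its limits.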

Compound 3, half-maximal inhibitory concentration: 69 nM
For compound 3 the middle estimate is 1.2-fold (0.06 log units) below the measured one, and the stated range covers the measured number.
By their numbers in this assay, from the lowest: compound 2; then compound 3; then compound 1.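

In this assay, the series now has its first comparison in one place: a 2.8-fold lower number from compound 1 to compound 3 (0.44 log units; beyond the scatter) with 4-hydroxy-4-methylcyclohexyl in place of cyclohexyl on an oxygen on an aromatic ring. This position therefore tolerates the larger group, which brings the counted hydrogen-bond donor and acceptor, and the modest step lies beyond the scatter in the direction of a stronger inhibitor. No measured evidence available here accounts for the size of this step.

The compounds shown leave open whether the hydroxyl, the methyl or both account for the step, a question that 4-hydroxycyclohexyl and 4-methylcyclohexyl at the same oxygen could address. From the compounds shown here alone, how the opposite stereochemical arrangement of the two groups, or a 4-aminocyclohexyl group in the same place, would read in this assay also remains open.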